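Fluoro-to-methyl swap on the sulfonyl aryl ring, two cores

A few compounds are considered here, and "the series" means these few. Any claim that something is new, unique, unknown or untested is made for them only; others in the source may bear on it.

Measured so far in a functional assay on 3T3-L1 cells (Mus musculus) for inhibition, with a stated time of 20 min, tested at 20 uM; a higher number here means more inhibition at the concentration tested (going by the name of the read-out), a lower number less inhibition:
compound 1 `O=S(=O)(c1ccc(F)cc1)N(Cc1ccccc1)Cc1cccc(F)c1F` gives -81.9%
compound 2 `Cc1ccc(S(=O)(=O)N(Cc2ccccc2)Cc2cccc(F)c2F)cc1` gives -35.7%
compound 3 `O=S(=O)(c1ccc(F)cc1)N(Cc1cccc(F)c1F)Cc1cn(S(=O)(=O)c2ccc(F)cc2)c2ccccc12` gives -20%

Compound 2 differs from compound 1 by methyl in place of fluoro on an aromatic carbon; this change moved the read-out a number 46.2 percentage points higher from compound 1 to compound 2 (beyond the scatter). Compound 3 carries a different core, and the difference between the two cores is not broken down here; its value stands above both compound 1 and compound 2 by more than the scatter.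

Compound 4 `Cc1ccc(S(=O)(=O)N(Cc2cccc(F)c2F)Cc2cn(S(=O)(=O)c3ccc(F)cc3)c3ccccc23)cc1` is not yet measured. It differs from compound 3 by methyl in place of fluoro on an aromatic carbon, the same change that was made from compound 1 to compound 2. Because the earlier step was a number 46.2 percentage points higher from compound 1 to compound 2 (beyond the scatter), a rise is expected again, though smaller: compound 3 already sits higher, and the expected step in this assay is a number 30 percentage points higher from compound 3 to compound 4 (beyond the scatter). Compound 4 is estimated at 10%, between -25% and 40%.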

Compound 4, a percentage reported as inhibition, at one concentration (the size of the read-out at that concentration, not a potency): -35%
Compound 4: the middle estimate sits 45 percentage points above what was measured; measured number outside the range, below it.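

In this assay, the swap from 4-fluorophenyl to 4-methylphenyl gives a number 15 percentage points lower from compound 3 to compound 4 (beyond the scatter). The change therefore does not carry from one core to the other, in either direction or size: the same change on two cores in this assay, a number 46.2 percentage points higher (beyond the scatter) from compound 1 to compound 2 and a number 15 percentage points lower (beyond the scatter) from compound 3 to compound 4, 61.2 percentage points apart, beyond the scatter of two such steps. This rests on a single pair per core, tested at a single concentration, and it does not show which part of the cores sets the difference or how the change would behave on a third core.

From the compounds shown here alone, it remains open whether a chloro, methoxy or amine group at the same place on the ring would follow the fluoro or the methyl result on each core. Also open, going by these compounds, is how each core responds to a chain longer than methyl there.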